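Swapping the Heteroaryl Amide Cap in an Acetogenin Series

The source may report more compounds than this note shows. Statements on the series, on what has been measured and on what is new or still open speak of the compounds shown alone.

Three analogues share one long-chain core and differ only in the aromatic ring attached to the terminal amide carbonyl. In a functional assay on HCT-15 cells (Homo sapiens) for inhibition, read by colorimetric assay and sulforhodamine B assay, with a stated time of 48 h (a higher number here means a weaker inhibitor of growth, a lower number a stronger inhibitor of growth), compound 1 `CCCCCCCCCCCC[C@@H](O)[C@H]1CC[C@H]([C@H](O)CCCCCCCCCCNC(=O)c2cncs2)O1` gives 100000 nM. Compound 2 `CCCCCCCCCCCC[C@@H](O)[C@H]1CC[C@H]([C@H](O)CCCCCCCCCCNC(=O)c2ccnn2C)O1` gives 100000 nM in this assay, and no change at the digits printed from compound 1 to compound 2 (within the scatter). Compound 3 `CCCCCCCCCCCC[C@@H](O)[C@H]1CC[C@H]([C@H](O)CCCCCCCCCCNC(=O)c2cccs2)O1` gives 5750 nM in this assay, which is the lowest of the three numbers; the two steps reaching it, a 17-fold lower number from compound 1 to compound 3 (1.24 log units; beyond the scatter) and a 17-fold lower number from compound 2 to compound 3 (1.24 log units; beyond the scatter), are both beyond the scatter, so compound 3 is the strongest growth inhibitor among the measured compounds.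

Compound 4 `CCCCCCCCCCCC[C@@H](O)[C@H]1CC[C@H]([C@H](O)CCCCCCCCCCNC(=O)c2ccoc2)O1` is not yet measured. Relative to compound 3 it carries furan-3-yl in place of thiophen-2-yl on a carbonyl carbon. Among the measured compounds shown here, no measured step exchanges one ring with a single hetero atom for another, so the only guidance is that the ring on the carbonyl can move the number a great deal, as the steps into compound 3 show, while the entering ring resembles the leaving one in its counted features more than either of the rings in compound 1 or compound 2 does. A modest weakening relative to compound 3 is therefore expected, with wide uncertainty, and the step is estimated as a 2.1-fold higher number from compound 3 to compound 4 (0.32 log units; beyond the scatter). For compound 4 the expected value in this assay is 12000 nM, within a range from 3000 nM to 60000 nM.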

Compound 4, concentration for 50% growth inhibition: 100000 nM
Compound 4: the middle estimate sits 8.3-fold (0.92 log units) below what was measured, and the stated range ends below it.
By their numbers in this assay, from the lowest: compound 3; then compounds 1, 2 and 4 (each within the scatter of the next).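

The step from thiophen-2-yl to furan-3-yl on a carbonyl carbon, a 17-fold higher number from compound 3 to compound 4 (1.24 log units; beyond the scatter) in this assay, shows that matching counted features do not keep the number here: both rings have 5 heavy atoms, one five-membered aromatic ring with 1 hetero atom, 0 hydrogen-bond donors and 1 hydrogen-bond acceptor. The other two steps, no change at the digits printed from compound 2 to compound 4 (within the scatter) and no change at the digits printed from compound 1 to compound 4 (within the scatter), place furan-3-yl level with the 1-methyl-1H-pyrazol-5-yl and 1,3-thiazol-5-yl rings, so among these four compounds only compound 3, with its thiophen-2-yl ring, stands apart from the rest. Nothing available beyond these growth numbers bears on why this exchange has so large an effect.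

This step changes two things at once, sulfur giving way to oxygen and the ring's attachment changing from the 2-yl to the 3-yl form, and the compounds shown cannot tell these apart, whereas furan-2-yl or thiophen-3-yl on the same carbonyl carbon could. From the compounds shown here alone, whether a ring outside this set, such as phenyl, would match or pass thiophen-2-yl also remains open.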